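Moving the bromine: from 3-bromophenyl to 4-bromophenyl

The source may report more compounds than this note shows. Statements on the series, on what has been measured and on what is new or still open speak of the compounds shown alone.

- Compound 1 `Fc1ccc(/C=N/Nc2nc(-c3ccc(C(F)(F)F)cc3)cs2)cc1F` gives 2610 nM
- Compound 2 `Fc1ccc(/C=N/Nc2nc(-c3cccc(Br)c3)cs2)cc1F` gives 16200 nM

Both values come from a functional assay on A549 cells (Homo sapiens) for inhibition, read by MTT assay, with a stated time of 48 h; on this read-out lower numbers stand for stronger inhibition and higher numbers for weaker inhibition. Compound 2 stands highest of the two, at 16200 nM, and so is the weaker inhibitor, with a gap to compound 1 beyond the usual scatter. Compound 3 `Fc1ccc(/C=N/Nc2nc(-c3ccc(Br)cc3)cs2)cc1F` has not yet been measured. It replaces the 3-bromophenyl of compound 2 with 4-bromophenyl on an aromatic carbon of the five-membered ring: 4-bromophenyl in place of 3-bromophenyl on an aromatic carbon. Within the data shown here, no measured step shows what this change does in this assay. Among the measured compounds shown here, the expected direction is downward, a thin inference resting only on compound 1 at 2610 nM, the one lower value available. The expected change, modestly beyond the scatter, is a 2.7-fold lower number from compound 2 to compound 3 (0.43 log units; beyond the scatter). For compound 3 the estimated value is 6000 nM, with an expected range of 2000 nM to 18000 nM.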

Compound 3, half-maximal inhibitory concentration: > 100000 nM
Compound 3 gave a limit, no number; the forecaster's own chance of this, stated with the estimate: 3%; middle value at least 16-fold (1.22 log units) from the limit.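

Compound 3 gives a limit of the assay, not a number: the limit of > 100000 nM in this assay, at which 1 of the 3 values shown sits.

In this assay, 4-bromophenyl in place of 3-bromophenyl, on an aromatic carbon of the five-membered ring and with the same atoms, gives an at least 6.1-fold higher number from compound 2 to compound 3 (0.79 log units; beyond the scatter), so the place of the bromine on the phenyl ring alone changes the read-out beyond the scatter. Bromo in place of trifluoromethyl on an aromatic carbon gives an at least 38-fold higher number from compound 1 to compound 3 (1.58 log units; beyond the scatter), so the group itself also decides the read-out, and a substituted phenyl ring does not by itself retain inhibition.

On these data alone, the full size of both steps stays open, as the limit of compound 3 gives only their lower bound. Also open, as far as these compounds go, is whether chloro, methoxy or an amine in place of the bromo would read closer to compound 1.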